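Halogen swap on the aromatic ring: compound 3 to compound 4

The compounds below may be only part of what the source reports. "The series", "measured", "known", "first", "only" and "open" are said of these compounds alone.

Compound 3 `O=C(CCC1=CCN(Cc2cccc(Br)c2)C1=O)NO` gives 4720 nM in a functional assay on HCT-15 cells (Homo sapiens) for inhibition, read by sulforhodamine B assay; a lower number here means a stronger inhibitor of growth, a higher number a weaker inhibitor of growth. Compound 2 `Cc1cccc(CN2CC=C(CCC(=O)NO)C2=O)c1` gives 4720 nM in this assay and compound 1 `O=C(CCC1=CCN(CCCc2ccc(Br)cc2)C1=O)NO` gives 5100 nM, so compound 3 sits level with compound 2 and within the scatter of compound 1; nothing separates the three. Compound 4 `O=C(CCC1=CCN(Cc2cccc(Cl)c2)C1=O)NO` differs from compound 3 by chloro in place of bromo on an aromatic carbon. For the measured compounds named here, the one measured step on the same aromatic carbon, no change at the digits printed from compound 2 to compound 3 (within the scatter), left the number unchanged, though it exchanged methyl for bromo, and no halogen-for-halogen step has been measured. The expected step of a 1.0-fold lower number from compound 3 to compound 4 (0.00 log units; within the scatter) is therefore none beyond the scatter. Compound 4 is estimated at 4700 nM, with a range from 2500 nM to 9000 nM.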

Compound 4, concentration for 50% growth inhibition: 4720 nM
Estimate against measurement, compound 4: 1.0-fold (0.00 log units) below, within the range that was stated.
By their numbers in this assay, from the lowest: compounds 2, 3, 4 and 1 (each within the scatter of the next).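

In this assay, for the compounds shown here, the first halogen-for-halogen step on this aromatic carbon, chloro in place of bromo, gives no change at the digits printed from compound 3 to compound 4 (within the scatter) and chloro in place of methyl gives no change at the digits printed from compound 2 to compound 4 (within the scatter) in the same series. Methyl, bromo and chloro at this place therefore cannot be told apart in this assay, which extends the earlier methyl-to-bromo result to a second halogen. No measurement at hand accounts for this lack of separation.

As far as these compounds go, whether fluoro, an amine or a carboxylic acid on this aromatic carbon would move the number beyond the scatter stays open. Also open, from the compounds shown here alone, is whether chloro would behave the same way on a longer chain such as that of compound 1.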